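The compounds below may be only part of what the source reports. "The series", "measured", "known", "first", "only" and "open" are said of these compounds alone.

Two compounds of the series carry measurements in a functional assay on the whole organism (strain Wistar albino) for inhibition, with Rattus norvegicus as the target, read by paw edema, in the formalin test, with stated times of 1 h and 3 h, at a dose of 20 mg/kg by the oral route; a higher number here means more inhibition at the dose given (going by the name of the read-out), a lower number less inhibition. Compound 1, `N#Cc1cnn(-c2ccccc2)c1NC(=O)C(=O)Nc1c(C#N)cnn1-c1ccccc1`, gives 50%, and compound 2, `CC(NC(=O)C(=O)Nc1c(C#N)cnn1-c1ccccc1)c1ccccc1`, gives 46%, the lower of the two numbers, though its gap to compound 1 lies within the scatter and no order is read from it. Compound 3, `C[C@@H](NC(=O)C(=O)Nc1c(C#N)cnn1-c1ccccc1)c1ccccc1`, awaits measurement in this assay. It differs from compound 2 in one point: the two compounds have the same atoms and bonds; at least one stereo element is drawn with a configuration in one of them and without one in the other: 1 of 1 stereo elements differ; a stereocentre at a saturated chain carbon is drawn without a configuration in compound 2 and R in compound 3. Among the compounds with values here, no measured pair shows what fixing such a configuration does, so no step beyond the scatter is expected in either direction. The expected step is a number 1 percentage points higher from compound 2 to compound 3 (within the scatter). Compound 3 is estimated at 47%, with a range of 32% to 62%.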

Compound 3, a percentage reported as inhibition, in the whole organism at one dose (the size of the read-out at that dose, not a potency): 44%
Compound 3: middle estimate off by 3 percentage points, on the high side; the measured number falls inside the stated range.
By their numbers in this assay, from the lowest: compounds 3, 2 and 1 (each within the scatter of the next).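

In this assay, the stereocentre at the saturated chain carbon can now be read on its own, and drawing it as R instead of without a configuration gives a number 2 percentage points lower from compound 2 to compound 3 (within the scatter). This pair therefore shows no step beyond the scatter at this position, and the comparison rests on a single structural difference: the fact that one of compounds 2 and 3 is drawn with a defined configuration and the other without, at the place where they differ

On these data alone, the S form of compound 3 remains open, so the two configurations cannot yet be set against each other. Also open, as far as these compounds go, is what a longer chain or a carboxylic acid would give in place of the methyl at this stereocentre.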